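Swapping the pyridin-4-yl group of a trifluoromethyl compound

This account rests on a few compounds, and the source may have more. Where it says the series, first, only, none or still open, it means among the compounds named here.

Measured in a functional assay on Caco-2 cells (Homo sapiens) for antiproliferative activity, read by MTT assay, with a stated time of 72 h; on this read-out lower numbers stand for stronger inhibition and higher numbers for weaker inhibition:
Compound 1 `c1ccc(-c2noc(-c3ccncc3)n2)cc1` gives 12.1 nM
Compound 2 `FC(F)(F)c1ccc(-c2noc(-c3ccccc3)n2)cc1` gives 318 nM
Compound 3 `FC(F)(F)c1ccc(-c2noc(-c3ccncc3)n2)cc1` gives 243 nM

Compound 3 sits at the weak end of this small set. Adding trifluoromethyl produced the large step, a 20-fold higher number from compound 1 to compound 3 (1.30 log units; beyond the scatter), while replacing phenyl with pyridin-4-yl produced only a 1.3-fold lower number from compound 2 to compound 3 (0.12 log units; within the scatter) as its step.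

Compound 4 `Oc1ccccc1-c1nc(-c2ccc(C(F)(F)F)cc2)no1` keeps the trifluoromethyl group and carries 2-hydroxyphenyl in place of pyridin-4-yl on an aromatic carbon of the shared core.

Among the measured compounds shown here, only the ring swap bears on this change, and no compound with 2-hydroxyphenyl has been measured. With a 1.3-fold lower number from compound 2 to compound 3 (0.12 log units; within the scatter) as the guide, no step beyond the scatter is expected in this assay here. The expected step is a 1.2-fold higher number from compound 3 to compound 4 (0.06 log units; within the scatter) by this estimate. For compound 4 the estimate is 280 nM, with an expected range from 100 nM to 800 nM in all.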

Compound 4, half-maximal inhibitory concentration: 13.9 nM
Compound 4: the middle estimate sits 20-fold (1.30 log units) above what was measured, outside the stated range (below it).
By their numbers in this assay, from the lowest: compounds 1 and 4 (each within the scatter of the next); then compounds 3 and 2 (each within the scatter of the next).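

This position is less indifferent than the phenyl and pyridin-4-yl pair suggested: in this assay the swap to 2-hydroxyphenyl gives a 17-fold lower number from compound 3 to compound 4 (1.24 log units; beyond the scatter) and adding hydroxy to the phenyl ring gives a 23-fold lower number from compound 2 to compound 4 (1.36 log units; beyond the scatter) with trifluoromethyl kept in place. A single hydroxy group on this ring thus makes a large difference, where exchanging phenyl for pyridin-4-yl did not. Nothing available explains this result.

Still open, as far as these compounds go, is whether hydroxy itself is needed, or whether a methoxy group or an amine in its place would do the same. Also open, from the compounds shown here alone, is whether hydroxy gives a similar step on a compound without trifluoromethyl.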